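Swapping Dimethoxyphenyl for Furan on the Shared Core

The source may hold more compounds than are shown below. What is called first, only, known or untested is meant among the compounds shown, and "the series" means these compounds.

Compound 1, `COc1ccc(-c2nc3cccc(-c4cc(OC)c(OC)c(OC)c4)c3o2)cc1OC`: 1300 nM
Compound 2, `COc1cc(-c2cccc3nc(-c4cccc(O)c4)oc23)cc(OC)c1OC`: 5500 nM

Of the compounds shown here, two built on the same core have been measured in a functional assay on U-251 cells (Homo sapiens) for antiproliferative activity, read by MTT assay, with a stated time of 48 h; on this read-out higher numbers stand for weaker inhibition and lower numbers for stronger inhibition. For the measured compounds named here, compound 1 stands at the lowest of the two numbers; its only neighbour is compound 2, reached by the step of a 4.2-fold higher number from compound 1 to compound 2 (0.63 log units; beyond the scatter), which came with 3-hydroxyphenyl in place of 3,4-dimethoxyphenyl on an aromatic carbon.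

Compound 3, `COc1cc(-c2cccc3nc(-c4ccco4)oc23)cc(OC)c1OC`, has not yet been measured. It differs from compound 1 in one place: furan-2-yl in place of 3,4-dimethoxyphenyl on an aromatic carbon. Going by the values given here, the one measured step that bears on this change is a 4.2-fold higher number from compound 1 to compound 2 (0.63 log units; beyond the scatter), where exchanging the 3,4-dimethoxyphenyl for another ring at the same position weakened inhibition to a modest degree. Exchanging it for furan-2-yl is expected to move the number in the same direction by a comparable amount, giving the expected step of a 3.1-fold higher number from compound 1 to compound 3 (0.49 log units; beyond the scatter). Compound 3 is therefore estimated to give about 4000 nM in this assay, with an expected range from 1500 nM to 12000 nM.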

Compound 3, half-maximal inhibitory concentration: 10600 nM
Beside the measured number, compound 3's estimate is 2.7-fold (0.42 log units) below it; the measured number falls inside the stated range.
By their numbers in this assay, from the lowest: compound 1; then compounds 2 and 3 (each within the scatter of the next).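

In this assay, putting furan-2-yl, a five-membered aromatic ring with 1 hetero atom, in place of the 3,4-dimethoxyphenyl gives (an 8.2-fold higher number from compound 1 to compound 3 (0.91 log units; beyond the scatter)), so a second replacement at this position, on the aromatic carbon next to the ring nitrogen and next to the ring oxygen, also weakens inhibition. Furan-2-yl and 3-hydroxyphenyl cannot be told apart here (a 1.9-fold higher number from compound 2 to compound 3 (0.28 log units; within the scatter)), even though one is a five-membered ring and the other a six-membered ring. Among these three compounds, then, the 3,4-dimethoxyphenyl of compound 1 gives the strongest inhibition, and both replacements fall short of it by more than the usual scatter, whether the new ring is six-membered or five-membered.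

Nothing measured here explains why either exchange weakens inhibition. From the compounds shown here alone, it remains open whether the methoxy groups or the ring itself matter more: a plain phenyl ring, a phenyl ring with a single methoxy group, or one carrying an amine or a carboxylic acid at this position would help separate the two.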